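A Longer Chain on Compound 1

The source may hold more compounds than are shown below. What is called first, only, known or untested is meant among the compounds shown, and "the series" means these compounds.

Compound 1 `CCCCCCC(CCO)n1cnc2c(Cl)ncnc21` gives 11900 nM
Compound 2 `CCCCCCC(CCO)n1c(Br)nc2c(Cl)ncnc21` gives 16100 nM
Compound 3 `CCCCCCC(CCO)n1cnc2cncnc21` gives > 50000 nM as a limit of the assay

Within the data shown here, in a functional assay on HCT-116 cells (Homo sapiens) for antiproliferative activity, read by MTT assay, with a stated time of 48 h (on this read-out higher numbers stand for weaker inhibition and lower numbers for stronger inhibition), compound 1 and compound 2 are the only two with numbers, and they lie within the scatter of each other. Compound 3 is reported only as a limit. Compound 4 `CCCCCCCCCC(CCO)n1cnc2c(Cl)ncnc21` keeps the core of compound 1 and differs in its chain. The change is propyl in place of hydrogen on a saturated chain carbon, seven bonds along the chain from an aromatic nitrogen and nothing else moves. Two measured steps are available, and both sit on an aromatic carbon. Bromo in place of hydrogen gave a 1.4-fold higher number from compound 1 to compound 2 (0.13 log units; within the scatter) and so made no clear difference. Hydrogen in place of chloro gave an at least 4.2-fold higher number from compound 1 to compound 3 (0.62 log units; beyond the scatter) and so made a clearer one. Neither step touches the saturated chain, so the data point in no direction for this change, and a step within the scatter is expected in this assay for compound 4. The expected step is a 1.3-fold lower number from compound 1 to compound 4 (0.12 log units; within the scatter) on this estimate. For compound 4 the estimated value is 9000 nM with an expected range from 3500 nM to 25000 nM in this assay.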

Compound 4, half-maximal inhibitory concentration: 890 nM
The estimate for compound 4 lay 10-fold (1.00 log units) above the measured number; measured number outside the range, below it.
By their numbers in this assay, from the lowest: compound 4; then compounds 1 and 2 (each within the scatter of the next). At a limit, above all of these: compound 3.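

The saturated chain turns out to be a place where the number in this assay can move a long way: propyl in place of hydrogen, seven bonds along the chain from an aromatic nitrogen, gave a 13-fold lower number from compound 1 to compound 4 (1.13 log units; beyond the scatter). The earlier steps shown here both sat on an aromatic carbon and so said nothing about the chain, whereas this one shows that the chain matters on this read-out, with the core of compound 1 unchanged. Nothing measured here speaks to why a step of this size occurs.

From the compounds shown here alone, whether a longer chain than propyl at this place would lower the number further, or would reverse the step, remains open. So does the question of whether an amine at the same place would give a step of similar size.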